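Chain lengthening of a hydroxamic acid on a second core

The source may report more compounds than this note shows. Statements on the series, on what has been measured and on what is new or still open speak of the compounds shown alone.

Compound 1 `Nc1ncnc2c1c(-c1cnc3[nH]ccc3c1)nn2CCCCCC(=O)NO` and compound 2 `Nc1ncnc2c1c(-c1cnc3[nH]ccc3c1)nn2CCC(=O)NO` share one core; compound 3 `Nc1nc2cc(-c3nn(CCCCCC(=O)NO)c4ncnc(N)c34)ccc2o1` and compound 4 `Nc1nc2cc(-c3nn(CCCCCCCCC(=O)NO)c4ncnc(N)c34)ccc2o1` share another, and the difference between the two cores is not broken down here. In a functional assay on HepG2 cells (Homo sapiens) for inhibition, read by MTT assay, with a stated time of 72 h (on this read-out lower numbers stand for stronger inhibition and higher numbers for weaker inhibition), compound 1 gives 12900 nM. For compound 2 this assay reports only a limit, > 150000 nM. The change 3-(hydroxycarbamoyl)propyl in place of hydroxycarbamoyl on a saturated chain carbon, two bonds along the chain from an aromatic nitrogen gave an at least 11-fold lower number from compound 2 to compound 1 (1.06 log units; beyond the scatter). Compound 3 gives 1990 nM in this assay. Compound 4 arises from compound 3 by 3-(hydroxycarbamoyl)propyl in place of hydroxycarbamoyl on a saturated chain carbon, five bonds along the chain from an aromatic nitrogen, the same kind of change, though here the place is five bonds rather than two bonds along the chain from the aromatic nitrogen. Resting on the earlier step and on compound 3 at 1990 nM, compound 4 is expected to give 3000 nM, a step of a 1.5-fold higher number from compound 3 to compound 4 (0.18 log units; within the scatter), smaller than the earlier step.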

Compound 4, half-maximal inhibitory concentration: 2610 nM
For compound 4 the middle estimate is 1.1-fold (0.06 log units) above the measured one; the measured number falls inside the stated range.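

In this assay, the same change on the core of compound 3 gave a 1.3-fold higher number from compound 3 to compound 4 (0.12 log units; within the scatter), so it did not carry over from the core of compound 1 with the size it had there, and the two steps differ: the same change on two cores in this assay, an at least 11-fold lower number (1.06 log units; beyond the scatter) from compound 2 to compound 1 and a 1.3-fold higher number (0.12 log units; within the scatter) from compound 3 to compound 4, at least 15-fold (1.18 log units) apart, beyond the scatter of two such steps The earlier step starts from compound 2, whose value is a limit and not a number: the limit of > 150000 nM in this assay, at which 1 of the 4 values shown sits. The comparison shows that the step is not constant across these two pairs, but it does not show whether the core or the place along the chain, two bonds against five, accounts for this, as the two vary together.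

The compounds shown leave open what the 2-(hydroxycarbamoyl)ethyl chain gives on the core of compound 3, which would compare both cores at the same place. They also leave open whether a carboxylic acid in place of hydroxycarbamoyl retains inhibition.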